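This account rests on a few compounds, and the source may have more. Where it says the series, first, only, none or still open, it means among the compounds named here.

Measured compounds:
- compound 1, `CC(=O)N1CCC(Oc2cncc(N3C(=O)c4ccc(Cl)cc4C3(C)C)c2)CC1` — in an assay on cells for inhibition of cytochrome P450 11B2, mitochondrial (Homo sapiens), read by HTRF (on this read-out lower numbers stand for stronger inhibition and higher numbers for weaker inhibition), compound 1 gives 4 nM
- compound 2, `O=C(Nc1cccnc1)c1ccc(Cl)cc1F` — in this assay compound 2 gives 297 nM

Compound 1 has the lowest number of the two, and the number for compound 2 lies far above it, well beyond the usual scatter of repeated measurements. No single-point comparison between these two is available, since their structures differ in more than one place; the values simply show compound 1 as the stronger inhibitor of the pair.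

The step under consideration leads from compound 1 to compound 3, `CC(=O)N1CC[C@H](Oc2cncc(N3C(=O)c4ccc(Cl)cc4C3(C)C)c2)C1`. The change is 1-acetylpyrrolidin-3-yl in place of 1-acetylpiperidin-4-yl on an oxygen on an aromatic ring. The acetylated ring on the oxygen is thus made smaller by one carbon, and its attachment point acquires a defined stereocentre, while the rest of the molecule is unchanged.

Within the data shown here, no measured pair shows what such a change does here, so the expectation rests on the closeness of the two structures alone. For compound 3 the step from compound 1 is expected to be small, a 2.0-fold higher number from compound 1 to compound 3 (0.30 log units; within the scatter), with a slight lean towards a higher number. Compound 3 is therefore estimated at 8 nM, within a range from 2 nM to 30 nM.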

Compound 3, half-maximal inhibitory concentration: 7 nM
The estimate for compound 3 lay 1.1-fold (0.06 log units) above the measured number; the range from low to high includes it.
By their numbers in this assay, from the lowest: compounds 1 and 3 (each within the scatter of the next); then compound 2.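

In this assay the move on the oxygen from 1-acetylpiperidin-4-yl to 1-acetylpyrrolidin-3-yl gives a 1.8-fold higher number from compound 1 to compound 3 (0.24 log units; within the scatter) and so stays within the usual scatter. Among these compounds, this is the first comparison at this position in which only one place differs, and it shows that the six-membered ring can give way to a five-membered ring carrying one defined stereocentre without a step that can be told apart from repeat-measurement noise, as long as the acetyl group stays on the ring nitrogen. Nothing available here explains why the two rings read alike.

The compounds shown leave open what the opposite stereocentre of the 1-acetylpyrrolidin-3-yl group would give, so the part played by the stereocentre in this result cannot be judged. Going by these compounds, it is also open how far this position tolerates changes to the acetyl group itself, for example a free amine on the ring, a methanesulfonyl group on the ring nitrogen, or a longer chain such as propanoyl in its place.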